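The source may report more compounds than this note shows. Statements on the series, on what has been measured and on what is new or still open speak of the compounds shown alone.

Three compounds sharing one saturated core carry different groups on a saturated chain carbon bound to a saturated ring carbon. Compound 1 `CCSCCC12CCC(c3nnc(-c4ccccc4C(F)(F)F)n3C)(CC1)CC2` gives 79% in a functional assay on the whole organism (strain ICR) for inhibition, with Mus musculus as the target, with a stated time of 4 h, at a dose of 10 mg/kg by the oral route; a higher number here means more inhibition at the dose given (going by the name of the read-out), a lower number less inhibition. Compound 2 `Cn1c(-c2ccccc2C(F)(F)F)nnc1C12CCC(CNS(C)(=O)=O)(CC1)CC2` gives 73% in this assay, and compound 3 `Cn1c(-c2ccccc2C(F)(F)F)nnc1C12CCC(COc3ccc(S(C)(=O)=O)cc3)(CC1)CC2` gives 79% in this assay. Compound 3 stands level with compound 1, the step being no change at the digits printed from compound 1 to compound 3 (within the scatter), and lies within the scatter of compound 2, the step being a number 6 percentage points higher from compound 2 to compound 3 (within the scatter). The step of a number 6 percentage points lower from compound 1 to compound 2 (within the scatter) is likewise within the scatter.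

Compound 4 `CC(F)CCCC12CCC(c3nnc(-c4ccccc4C(F)(F)F)n3C)(CC1)CC2` differs from compound 3 by 3-fluorobutyl in place of 4-(methylsulfonyl)phenoxy on a saturated chain carbon bound to a saturated ring carbon. Every measured step at this chain position, whether toward a sulfonamide, a sulfonylphenoxy group or an ethylsulfanylmethyl group, stayed within the scatter, so the exchange to 3-fluorobutyl is expected to give a step of about a number 2 percentage points lower from compound 3 to compound 4 (within the scatter), none beyond the scatter. For compound 4 the expected value in this assay is 77%, estimated to fall between 60% and 92%.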

Compound 4, a percentage reported as inhibition, in the whole organism at one dose (the size of the read-out at that dose, not a potency): 96%
Compound 4: middle estimate off by 19 percentage points, on the low side; the whole stated range lies below it.
By their numbers in this assay, from the lowest: compounds 2, 1 and 3 (each within the scatter of the next); then compound 4.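

Until compound 4, every exchange at this position on a saturated chain carbon bound to a saturated ring carbon had stayed within the scatter in this assay, but 3-fluorobutyl gives a clear separation from the sulfonyl-bearing groups (a number 17 percentage points higher from compound 3 to compound 4 (beyond the scatter); a number 23 percentage points higher from compound 2 to compound 4 (beyond the scatter)). Read as 2-fluoropropyl in place of ethylsulfanyl, the change also stands out against the sulfur-bearing chain of compound 1 (a number 17 percentage points higher from compound 1 to compound 4 (beyond the scatter)), so the absence of a ring cannot be the whole story, as compound 1 also lacks a ring in this group yet stays within the scatter of compound 3. Nothing given here explains the rise.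

The compounds shown leave open whether the fluorine or the carbon chain carries this step, a question that a plain butyl chain would address. A single oral dose also leaves the potency of compound 4 open.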